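Swapping the sulfone for a fluorinated sulfoxide

The compounds below may be only part of what the source reports. "The series", "measured", "known", "first", "only" and "open" are said of these compounds alone.

Compound 1 `CC(C)OC(=O)N1CCC(Oc2ncnc3c2CCN3c2ccc(S(C)(=O)=O)cc2)CC1` is the reference point here. In a functional assay on CHO-K1 cells with Glucose-dependent insulinotropic receptor (Homo sapiens) as the target, read by a luciferase reporter, with a stated time of 5 h (a higher number here means a larger maximal response, a lower number a smaller maximal response), compound 1 gives 154%, the higher of the two values recorded. For the measured compounds named here, the only other measured compound, compound 2 `N#CN1CCC(O)CC1`, reaches 129% in this assay, a gap beyond the usual scatter of repeated measurements of this kind. Going by the values given here, no pair of measured compounds differing in a single place is available, so nothing directly shows how a change to the group on a nitrogen on an aromatic ring in a ring alters the maximal response.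

Compound 3 `CC(C)OC(=O)N1CCC(Oc2ncnc3c2CCN3c2ccc([S@@+](C)[O-])c(F)c2)CC1` differs from compound 1 in exactly one place: a group of 10 heavy atoms (7 carbon, 1 oxygen, 1 fluorine, 1 sulfur; one six-membered aromatic ring of carbon only) in place of a group of 10 heavy atoms (7 carbon, 2 oxygen, 1 sulfur; one six-membered aromatic ring of carbon only), on a nitrogen on an aromatic ring in a ring. Among the compounds with values here, with no comparable measured step to lean on, the expected step, a number 9 percentage points lower from compound 1 to compound 3 (within the scatter), is small and may well lie within the scatter. Compound 3 is therefore estimated to give 145% in this assay, with a range from 110% to 175%.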

Compound 3, largest response reached (reported as percent of maximum), in percent of the reference or control that the assay uses: 155%
The estimate for compound 3 lay 10 percentage points below the measured number; the measured number falls inside the stated range.
By their numbers in this assay, from the lowest: compound 2; then compounds 1 and 3 (each within the scatter of the next).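

In this assay, for the compounds shown here, the first single-place step at this position reads a number 1 percentage points higher from compound 1 to compound 3 (within the scatter), so compound 1 and compound 3 cannot be told apart. On a nitrogen on an aromatic ring in a ring, then, the 4-(methylsulfonyl)phenyl group can give way to a fluorinated ring carrying a sulfoxide with a defined stereocentre, and the maximal response stays at the same high level within the scatter. No measurement shown offers a reason for this match.

As far as these compounds go, the step changes the sulfur group and adds fluorine at once, so the share of each remains open, as does any contribution from the sulfoxide's stereochemistry. From the compounds shown here alone, it also remains open whether a quite different group on this ring, such as a nitrile or a carboxylic acid, would give a similar response.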